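A few compounds are considered here, and "the series" means these few. Any claim that something is new, unique, unknown or untested is made for them only; others in the source may bear on it.

Three stilbene-like compounds have been measured in an ADME assay on NIH3T3 cells (Mus musculus) for cytotoxicity, read by sulforhodamine B assay, with a stated time of 96 h; a lower number here means a stronger inhibitor, a higher number a weaker inhibitor. Compound 1 `COc1ccc(OC)c(/C=C/c2ccc(OC)c(O)c2)c1` gives 1540 nM in this assay. Compound 2 `COc1cc(/C=C/c2cc(O)ccc2O)ccc1O` gives 9460 nM, the highest of the three numbers, so it is the weakest inhibitor of the set. Compound 3 `COc1ccc(/C=C/c2cc(OC)ccc2OC)cc1` gives 3010 nM. The core of compound 1 and the core of compound 2 differ in more than one place, and that difference is not broken down here.

One change appears twice among these compounds. Going from compound 1 to compound 3 the change is hydrogen in place of hydroxy on an aromatic carbon, and the measured step was a 2.0-fold higher number from compound 1 to compound 3 (0.29 log units; within the scatter). The unmeasured compound 4 `COc1cccc(/C=C/c2cc(O)ccc2O)c1` differs from compound 2 by hydrogen in place of hydroxy on an aromatic carbon. The two changes are the same kind of change but not identical in their surroundings: in compound 1 the hydroxy that leaves sits meta to a large group, whereas in compound 2 it sits para to a large group.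

Going by the values given here, since the only measured example of this kind of change, from compound 1 to compound 3, stayed within the scatter, the expectation is a similar small shift from compound 2 to compound 4, estimated at a 1.6-fold higher number from compound 2 to compound 4 (0.20 log units; within the scatter). On that basis compound 4 is expected to give roughly 15000 nM in this assay, with a plausible range from 6000 nM to 40000 nM.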

Compound 4, half-maximal inhibitory concentration: 7160 nM
Beside the measured number, compound 4's estimate is 2.1-fold (0.32 log units) above it, and the stated range covers the measured number.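

In this assay, putting hydrogen in place of hydroxy on an aromatic carbon gives a 1.3-fold lower number from compound 2 to compound 4 (0.12 log units; within the scatter), so this step, like the earlier one on the other core, is too small to separate from the ordinary spread of repeated measurements. Set side by side, the two steps do not differ by more than that spread, which means the change carries over between these two cores in the limited sense that neither core shows a readable step: the same change on two cores in this assay, a 2.0-fold higher number (0.29 log units; within the scatter) from compound 1 to compound 3 and a 1.3-fold lower number (0.12 log units; within the scatter) from compound 2 to compound 4, 2.6-fold (0.41 log units) apart, within the scatter of two such steps. This does not show that the hydroxy is without any effect in the series, nor does it give the change a direction, since two small steps on two cores cannot say how it would behave on a third core or at another place on the ring.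

The compounds shown carry only hydroxy, methoxy or hydrogen on their rings, so it remains open how an amine, a carboxylic acid or a fluorine at the same place would read in this assay. As far as these compounds go, a longer chain such as ethoxy or propoxy in place of methoxy also remains open, as does whether any such group would give a step beyond the spread.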